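The compounds below may be only part of what the source reports. "The series", "measured", "known", "first", "only" and "open" are said of these compounds alone.

Compound 2 `COc1ccc(/C=C/C(=O)OC/C=C/c2cc(OC)c(OC)cc2OC)cc1` and compound 1 `COc1ccccc1/C=C/C(=O)OC/C=C/c1cc(OC)c(OC)cc1OC` share one core and differ only in where the methoxy sits. In a functional assay on the whole organism (strain Kunming) with Mus musculus as the target, with a stated time of 0.5 h, at a dose of 300 mg/kg by the intraperitoneal route (a higher number here means a weaker effect of the compound at the dose given, a lower number a stronger effect), compound 1 gives 100%, and compound 2 gives 100%, so compound 2 stands level with compound 1, as the step of no change at the digits printed from compound 1 to compound 2 (within the scatter) shows. Compound 3 `COc1cc(OC)c(OC)cc1/C=C/COC(=O)/C=C/c1ccc(Cl)cc1` differs from compound 2 by chloro in place of methoxy on an aromatic carbon. For the measured compounds named here, no measured step swaps a methoxy for a chloro, so the only guide is the flat step from compound 1 to compound 2. Compound 3 is therefore expected to show no step beyond the scatter, no change at the digits printed from compound 2 to compound 3 (within the scatter), with an estimated 100% between 80% and 100%.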

Compound 3, a percentage reported as activity, at one dose (the size of the read-out at that dose, not a potency): 100%
For compound 3 middle estimate and measured number coincide at the digits printed; measured number inside the range.
By their numbers in this assay, from the lowest: compounds 1, 2 and 3 (each within the scatter of the next).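

In this assay, chloro on the aromatic carbon in place of methoxy leaves the read-out flat (no change at the digits printed from compound 2 to compound 3 (within the scatter)), so this position now shows a change of group, not only a shift of the methoxy, without a step beyond the scatter. The 4-chlorophenyl set against the 2-methoxyphenyl reads the same (no change at the digits printed from compound 1 to compound 3 (within the scatter)). Nothing measured here offers an explanation for this flat result. Going by these compounds, what an amine or a carboxylic acid on this aromatic carbon would give remains open, and so does whether any group here would bring the number down at this dose.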